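Series notes: trifluoromethyl in place of bromo

The compounds below may be only part of what the source reports. "The series", "measured", "known", "first", "only" and "open" are said of these compounds alone.

Compound 3 `CCOC(=O)c1oc2ccc(NS(=O)(=O)c3ccc(Br)cc3)cc2c1C` gives 56500 nM in a functional assay on MCF7 cells (Homo sapiens) for antiproliferative activity, read by MTT assay, with a stated time of 72 h (on this read-out higher numbers stand for weaker inhibition and lower numbers for stronger inhibition), and holds the lowest of the two numbers, with compound 1 `CCOC(=O)c1oc2ccc(NS(=O)(=O)c3ccc(Cl)cc3)cc2c1C` nearest at 81200 nM, a gap within the scatter. Compound 2 `CCOC(=O)c1oc2ccc(NS(=O)(=O)c3ccccc3Cl)cc2c1C` reports only a limit in this assay, > 200000 nM (the limit of > 200000 nM in this assay, at which 1 of the 3 values shown sits). Compound 4 `CCOC(=O)c1oc2ccc(NS(=O)(=O)c3ccc(C(F)(F)F)cc3)cc2c1C` differs from compound 3 by trifluoromethyl in place of bromo on an aromatic carbon. The measured step closest to this change is a 1.4-fold lower number from compound 1 to compound 3 (0.16 log units; within the scatter), a halogen swap on an aromatic carbon that stayed within the scatter; the other steps, an at least 2.4-fold higher number from compound 1 to compound 2 (0.39 log units; beyond the scatter) and an at least 3.5-fold lower number from compound 2 to compound 3 (0.54 log units; beyond the scatter), exchange one substituted phenyl for another on the sulfonyl sulfur and bear less on it. The step of a 1.1-fold higher number from compound 3 to compound 4 (0.03 log units; within the scatter) is therefore expected to stay within the scatter. Compound 4 is estimated at 60000 nM, within a range of 25000 nM to 150000 nM.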

Compound 4, half-maximal inhibitory concentration: 48700 nM
Estimate against measurement, compound 4: 1.2-fold (0.09 log units) above; measured number inside the range.
By their numbers in this assay, from the lowest: compounds 4, 3 and 1 (each within the scatter of the next). At a limit, above all of these: compound 2.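

Trifluoromethyl on the aromatic carbon para to a large group leaves the number in this assay unchanged within the scatter, with a 1.2-fold lower number from compound 3 to compound 4 (0.06 log units; within the scatter) and a 1.7-fold lower number from compound 1 to compound 4 (0.22 log units; within the scatter). Until now only two halogens had been compared at this position; a non-halogen group of 4 heavy atoms now gives no step beyond the scatter, so compound 1, compound 3 and compound 4 stand level. No measured property bears on this result.

Going by these compounds, whether an amine or a carboxylic acid at this position would move the number beyond the scatter stays open.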